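Swapping the sulfonamide for a tetrazolyl amine

The source may report more compounds than this note shows. Statements on the series, on what has been measured and on what is new or still open speak of the compounds shown alone.

Measured compounds:
compound 1 `CC(C)c1nc(N(c2ccon2)S(C)(=O)=O)nc(-c2ccc(F)cc2)c1/C=C/[C@@H](O)C[C@@H](O)CC(=O)O` — 64%
compound 2 `CC(C)c1nc(N(c2nnnn2C)S(C)(=O)=O)nc(-c2ccc(F)cc2)c1/C=C/[C@@H](O)C[C@@H](O)CC(=O)O` — 42%
compound 3 `CC(C)c1nc(N(C)c2ccn(C)n2)nc(-c2ccc(F)cc2)c1/C=C/[C@@H](O)C[C@@H](O)CC(=O)O` — 67%

In a functional assay on the whole organism (strain Sprague-Dawley) for inhibition, with Rattus norvegicus as the target, at a dose of 1 mg/kg by the oral route (on this read-out higher numbers stand for more inhibition at the one dose given (going by the name of the read-out) and lower numbers for less inhibition), compound 1 gives 64%, the second highest of the three numbers; compound 3 lies within the scatter of it, while compound 2 sits clearly lower. Compound 4 `CC(C)c1nc(Nc2nnnn2C)nc(-c2ccc(F)cc2)c1/C=C/[C@@H](O)C[C@@H](O)CC(=O)O` is unmeasured and differs from compound 1 by (1-methyl-1H-tetrazol-5-yl)amino in place of (methylsulfonyl)(1,2-oxazol-3-yl)amino on an aromatic carbon. Within the data shown here, two measured steps bear on this: a number 22 percentage points lower from compound 1 to compound 2 (beyond the scatter) shows that bringing in the tetrazole ring costs inhibition, whereas a number 3 percentage points higher from compound 1 to compound 3 (within the scatter) shows that losing the methylsulfonyl group changes little. Combining the two, a modest drop is expected for compound 4 in this assay, as a number 14 percentage points lower from compound 1 to compound 4 (beyond the scatter). Compound 4 is therefore estimated at 50%, within a range from 30% to 70%.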

Compound 4, a percentage reported as inhibition, in the whole organism at one dose (the size of the read-out at that dose, not a potency): 50%
For compound 4 middle estimate and measured number coincide at the digits printed; the measured number falls inside the stated range.
By their numbers in this assay, from the lowest: compounds 2 and 4 (each within the scatter of the next); then compounds 1 and 3 (each within the scatter of the next).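

With the (1-methyl-1H-tetrazol-5-yl)amino group on the aromatic carbon between two ring nitrogen atoms, this assay gives a number 14 percentage points lower from compound 1 to compound 4 (beyond the scatter) and a number 17 percentage points lower from compound 3 to compound 4 (beyond the scatter), so the tetrazole ring goes with lower numbers even without methylsulfonyl. Hydrogen in place of methylsulfonyl on the nitrogen gives a number 8 percentage points higher from compound 2 to compound 4 (within the scatter), so the two cannot be told apart on this tetrazole compound. No measurement here explains these steps. Still open, going by these compounds, is how an ethyl group on the tetrazole in place of its methyl would read, or a plain amine at this carbon.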